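The compounds below may be only part of what the source reports. "The series", "measured", "known", "first", "only" and "open" are said of these compounds alone.

In a functional assay on MCF7 cells (Homo sapiens) for inhibition, read by sulforhodamine B assay, with a stated time of 48 h (a lower number here means a stronger inhibitor, a higher number a weaker inhibitor), the measured compounds gave:

compound 1, `Cc1cc(C)cc(/C=C/c2ccc(N3CCNC3=O)cc2)c1`: 16000 nM
compound 2, `CCNC(=O)Nc1ccc(/C=C/c2cc(OC)c(OC)c(OC)c2)cc1`: 17000 nM
compound 3, `COc1cc(/C=C/c2ccc(N3CCNC3=O)cc2)cc(OC)c1OC`: 540 nM

Compound 3 and compound 2 share a core and differ in one place: (ethylcarbamoyl)amino in place of 2-oxoimidazolidin-1-yl on an aromatic carbon. That single change made a step of a 31-fold higher number from compound 3 to compound 2 (1.50 log units; beyond the scatter), a large loss of potency. Compound 4, `CCNC(=O)Nc1ccc(/C=C/c2cc(C)cc(C)c2)cc1`, has not yet been measured; it stands to compound 1 as compound 2 stands to compound 3, the same change in the same place: (ethylcarbamoyl)amino in place of 2-oxoimidazolidin-1-yl on an aromatic carbon. How the core of compound 1 differs from the core of compound 3 is not broken down here. Compound 1 and compound 2 lie within the scatter of each other, so nothing separates them.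

Within the data shown here, because the only precedent, a 31-fold higher number from compound 3 to compound 2 (1.50 log units; beyond the scatter), was a large loss, compound 4 is expected to be weaker than compound 1, though compound 1 is already weak and the step may not carry over fully, so the expected step from compound 1 to compound 4 is a 3.8-fold higher number from compound 1 to compound 4 (0.57 log units; beyond the scatter). Compound 4 is therefore estimated at 60000 nM, between 15000 nM and 200000 nM, with a real chance that this assay reports only a limit.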

Compound 4, half-maximal inhibitory concentration: 20000 nM
The estimate for compound 4 lay 3.0-fold (0.48 log units) above the measured number, and the stated range covers the measured number.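

In this assay, putting (ethylcarbamoyl)amino in place of 2-oxoimidazolidin-1-yl gave a 1.3-fold higher number from compound 1 to compound 4 (0.10 log units; within the scatter), so on this core the change has no effect that can be told apart from the scatter. The large loss seen with the same change on the other core therefore did not carry over, and in this series the size of the step depends on the core that carries it: the same change on two cores in this assay, a 31-fold higher number (1.50 log units; beyond the scatter) from compound 3 to compound 2 and a 1.3-fold higher number (0.10 log units; within the scatter) from compound 1 to compound 4, 25-fold (1.40 log units) apart, beyond the scatter of two such steps. Among these compounds, with only two pairs, this does not show which part of the cores decides the outcome, nor what the change would do on a third core.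

The compounds shown leave open how other groups would fare in the same place, such as a plain amine, a carboxylic acid, or a longer chain in place of the ethyl. On these data alone, it also remains open whether a further core, for example one bearing ethoxy groups, would follow compound 1 or compound 3.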